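The source may hold more compounds than are shown below. What is called first, only, known or untested is meant among the compounds shown, and "the series" means these compounds.

Measured so far:
- compound 1, `CCCCCCCCCCCCCCCC(=O)O[C@H]1[C@H](O)[C@H](n2ccc(N)nc2=O)O[C@@H]1CO`: 0.24 ug/mL
- compound 2, `CCCCCCCCCCCC(=O)OC[C@H]1O[C@@H](n2ccc(N)nc2=O)[C@@H](O)[C@@H]1OC(=O)CCCCCCCCCCC`: 0.5 ug/mL
- compound 3, `CCCCCCCC/C=C\CCCCCCCCCCCC(=O)O[C@H]1[C@H](O)[C@H](n2ccc(N)nc2=O)O[C@@H]1CO`: 0.16 ug/mL

All three share one core and differ only in the fatty acid chains attached to it. In a functional assay on HeLa cells (Homo sapiens) for cytotoxicity, read by cell counting, with a stated time of 48 h (a lower number here means that less compound is needed, a higher number that more compound is needed for the effect), compound 1 stands second of the three numbers. Its nearest neighbour is compound 3, and the step of a 1.5-fold lower number from compound 1 to compound 3 (0.18 log units; within the scatter) is within the scatter, so the two cannot be told apart. Among the compounds with values here, compound 2, which carries two shorter chains on different positions, gives a number that is beyond the scatter from compound 1, but no single-point step connects those two.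

The next compound, compound 4, `CCCCCCCC(=O)O[C@H]1[C@H](O)[C@H](n2ccc(N)nc2=O)O[C@@H]1CO`, is obtained from compound 1 by the change (hydrogen in place of octyl on a saturated chain carbon, seven bonds along the chain from a carbonyl carbon), a marked shortening of the single ester chain. Within the data shown here, no measured step covers a shortening of this kind; the only chain change seen, from compound 1 to compound 3, made the chain longer and stayed within the scatter. Among the measured compounds shown here, with that step as the only guide, the expectation for compound 4 in this assay is a modest shift towards a higher number, of the size a 2.5-fold higher number from compound 1 to compound 4 (0.40 log units; beyond the scatter), with wide uncertainty in both directions. Compound 4 is therefore estimated at 0.6 ug/mL, with a range from 0.2 ug/mL to 2 ug/mL.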

Compound 4, concentration for half-maximal effect: 0.1 ug/mL
Beside the measured number, compound 4's estimate is 6.0-fold (0.78 log units) above it, and the stated range ends above it.
By their numbers in this assay, from the lowest: compounds 4, 3 and 1 (each within the scatter of the next, the first and the last beyond it); then compound 2.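

Within the data shown here, removing the octyl end of the ester chain does not raise the number in this assay as the earlier compounds might have suggested: with hydrogen in place of octyl, seven bonds along the chain from a carbonyl carbon, the step is a 2.4-fold lower number from compound 1 to compound 4 (0.38 log units; beyond the scatter) and less compound is needed for the effect. Among these compounds, the only earlier chain step, a 1.5-fold lower number from compound 1 to compound 3 (0.18 log units; within the scatter) made the chain longer and could not be told from no change, whereas this step lies beyond the scatter and shows that the full chain of compound 1 is not required for the effect, although the step is modest. Nothing available on these compounds accounts for the shift, so its origin stays unknown.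

The compounds shown do not tell how far the chain can be cut before the number rises again, since nothing shorter than the chain of compound 4 appears among them. They also leave open what a chain ending in an amine or a carboxylic acid would do in this assay and whether the same shortening would hold for the two chains of compound 2.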